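The source may hold more compounds than are shown below. What is called first, only, known or untested is meant among the compounds shown, and "the series" means these compounds.

In an assay on CHO cells for displacement of a labelled ligand from adenosine receptor A1 (Homo sapiens), read by scintillation counting, with a stated time of 60 min, tested at 10 uM (a lower number here means less inhibition, a higher number more inhibition at the concentration tested (going by the name of the read-out)), compound 1 `CNC(=O)[C@@]12C[C@@H]1[C@@H](n1cnc3c(NC)nc(C#Cc4ccc(-c5ccccc5)cc4)nc31)[C@H](O)[C@@H]2O` gives 18%, compound 2 `CNC(=O)[C@@]12C[C@@H]1[C@@H](n1cnc3c(NC)nc(C#Cc4ccc(CO)cc4)nc31)[C@H](O)[C@@H]2O` gives 16%, and compound 3 `CNC(=O)[C@@]12C[C@@H]1[C@@H](n1cnc3c(NC)nc(C#Cc4cccnc4)nc31)[C@H](O)[C@@H]2O` gives 16%. Compound 3 thus sits level with compound 2 and together they are the lowest of the three numbers, while compound 1 stands a number 2 percentage points lower from compound 1 to compound 3 (within the scatter) apart; every gap among the three lies within the scatter. Compound 4 `CNC(=O)[C@@]12C[C@@H]1[C@@H](n1cnc3c(NC)nc(C#Cc4ccsc4)nc31)[C@H](O)[C@@H]2O` differs from compound 3 only at the aryl end of the alkyne: thiophen-3-yl in place of pyridin-3-yl on a triple-bonded carbon. Among the compounds with values here, two measured steps bear on this change, both exchanges of the aromatic group on the triple-bonded carbon: a number 2 percentage points lower from compound 1 to compound 3 (within the scatter) and no change at the digits printed from compound 2 to compound 3 (within the scatter). Neither moved the read-out beyond the scatter, and the third exchange on the ring, a number 2 percentage points lower from compound 1 to compound 2 (within the scatter), did the same. On this record the group at the end of the alkyne has not shifted the read-out in this assay, so a step of no change at the digits printed from compound 3 to compound 4 (within the scatter) is expected, meaning no change beyond the scatter. Compound 4 is therefore estimated at 16%, in the range 8% to 26%.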

Compound 4, a percentage reported as inhibition, at one concentration (the size of the read-out at that concentration, not a potency): 11%
The estimate for compound 4 lay 5 percentage points above the measured number, and the stated range covers the measured number.
By their numbers in this assay, from the lowest: compounds 4, 2, 3 and 1 (each within the scatter of the next).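

In this assay, a five-membered aromatic ring, thiophen-3-yl, now stands on the triple-bonded carbon, and the read-out stays within the scatter of each earlier compound (a number 5 percentage points lower from compound 3 to compound 4 (within the scatter); a number 5 percentage points lower from compound 2 to compound 4 (within the scatter); a number 7 percentage points lower from compound 1 to compound 4 (within the scatter)). Within the data shown here, the position has thus taken a sulfur-bearing ring as well as a nitrogen-bearing ring and two substituted phenyl rings, with no step among the four compounds beyond the scatter. No measurement is available that could explain these numbers.

From the compounds shown here alone, all four groups here are aromatic rings, so it remains open whether an amine, a carboxylic acid or a longer alkyl chain at the end of the alkyne would also stay within the scatter. A read-out at one concentration also leaves open how these compounds compare in potency.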